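A Phenyl Added to the Fused Core of Compound 1

The source may hold more compounds than are shown below. What is called first, only, known or untested is meant among the compounds shown, and "the series" means these compounds.

Within the data shown here, compound 1 `COc1ccccc1N1CCN(CCn2c(=O)[nH]c3cc[nH]c3c2=O)CC1` is one of two compounds measured in an assay for binding affinity to Adrenergic receptor alpha-1 (Rattus norvegicus); on this read-out lower numbers stand for stronger inhibition and higher numbers for weaker inhibition; in this assay compound 1 gives 2.31 nM, the highest of the two numbers. Compound 2 `O=c1[nH]c2cc[nH]c2c(=O)n1CCN1CCN(c2ccccc2Cl)CC1` gives 0.94 nM, and the step of a 2.5-fold lower number from compound 1 to compound 2 (0.39 log units; beyond the scatter) came with chloro in place of methoxy on an aromatic carbon. Compound 3 `COc1ccccc1N1CCN(CCn2c(=O)[nH]c3cc(-c4ccccc4)[nH]c3c2=O)CC1` differs from compound 1 by phenyl in place of hydrogen on an aromatic carbon. Among the measured compounds shown here, the only measured step concerns a different part of the shared core, so no measured step bears on this change. The expected step of a 1.3-fold higher number from compound 1 to compound 3 (0.11 log units; within the scatter) is therefore none beyond the scatter. Compound 3 is estimated at 3 nM, within a range of 0.8 nM to 12 nM.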

Compound 3, inhibition constant: 0.52 nM
For compound 3 the middle estimate is 5.8-fold (0.76 log units) above the measured one; measured number outside the range, below it.
By their numbers in this assay, from the lowest: compounds 3 and 2 (each within the scatter of the next); then compound 1.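

Placing phenyl on this aromatic carbon of the five-membered aromatic ring, next to the ring nitrogen, gives a 4.4-fold lower number from compound 1 to compound 3 (0.65 log units; beyond the scatter) in this assay. The result shows that this position can carry an added six-membered aromatic ring with no loss of binding, whereas the earlier step, chloro in place of methoxy, involved a different part of the compounds. Nothing shown here explains the lower number.

As far as these compounds go, it remains open whether a smaller group such as methyl would have a similar effect at this position. It is also unknown whether phenyl and chloro together in one compound would lower the number further.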